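The compounds below may be only part of what the source reports. "The series", "measured", "known", "first", "only" and "open" are said of these compounds alone.

Measured compounds:
compound 1 `Cc1ccccc1Oc1cccc(COc2ccccc2CCC(=O)OCCCOP(=O)(O)OC[C@H](N)C(=O)O)c1` — 0.28
compound 2 `N[C@@H](COP(=O)(O)OCCCOC(=O)CCc1ccccc1OCc1cccc(Oc2ccc(Cl)c(Cl)c2)c1)C(=O)O` — 0.71
compound 3 `N[C@@H](COP(=O)(O)OCCCOC(=O)CCc1ccccc1OCc1cccc(Oc2ccc(I)cc2)c1)C(=O)O` — 0.82

In an assay on cells for activation of probable G-protein coupled receptor 34 (Mus musculus), with a stated time of 1 h (on this read-out lower numbers stand for smaller maximal responses and higher numbers for larger maximal responses), compound 3 stands highest of the three numbers. The nearest step is a number 0.11 higher from compound 2 to compound 3 (beyond the scatter); the furthest is a number 0.54 higher from compound 1 to compound 3 (beyond the scatter). All three measured steps, including a number 0.43 higher from compound 1 to compound 2 (beyond the scatter), lie beyond the scatter and concern the aryl group on the oxygen.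

Compound 4 `CCc1ccc(Oc2cccc(COc3ccccc3CCC(=O)OCCCOP(=O)(O)OC[C@H](N)C(=O)O)c2)cc1` differs from compound 3 as follows: ethyl in place of iodo on an aromatic carbon. Among the compounds with values here, no measured step exchanges iodo for ethyl at an aromatic carbon, so the known steps bear on it only loosely, through the sensitivity of this position to the aryl group. A moderate downward step in this assay is expected, a number 0.17 lower from compound 3 to compound 4 (beyond the scatter). Compound 4 is estimated at 0.65, in a range from 0.4 to 0.9.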

Compound 4, intrinsic activity: the largest response reached, as a fraction of the reference agonist's: 0.42
Beside the measured number, compound 4's estimate is 0.23 above it; low and high end bracket the measured number.
By their numbers in this assay, from the lowest: compound 1; then compound 4; then compound 2; then compound 3.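

With the rest of the structure held, the group on this aromatic carbon has a large effect in this assay: ethyl in place of iodo gives a number 0.40 lower from compound 3 to compound 4 (beyond the scatter) and removes much of the maximal response. The 4-ethylphenyl group also gives a number 0.29 lower from compound 2 to compound 4 (beyond the scatter) against 3,4-dichlorophenyl and a number 0.14 higher from compound 1 to compound 4 (beyond the scatter) against 2-methylphenyl, placing it between them. No evidence on the cause of these steps is available.

Still open, on these data alone, is how bromo, methoxy, an amine or a longer chain such as propyl at this aromatic carbon would compare with iodo and ethyl.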